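Moving a Fluorine Around a Benzyl Ring: Cytotoxicity

The compounds below may be only part of what the source reports. "The series", "measured", "known", "first", "only" and "open" are said of these compounds alone.

Measured compounds:
- compound 1, `O=c1cc(NCc2cccc(F)c2)sc2c([N+](=O)[O-])cc(C(F)(F)F)cc12`: > 64 ug/mL
- compound 2, `CN(Cc1ccc2c(c1)OCCO2)c1cc(=O)c2cc(C(F)(F)F)cc([N+](=O)[O-])c2s1`: > 64 ug/mL

Both compounds were tested in an ADME assay on Vero cells (Chlorocebus sabaeus) for cytotoxicity, read by MTT assay, with a stated time of 48 h; on this read-out higher numbers stand for weaker inhibition and lower numbers for stronger inhibition. Compound 1 reached only a limit of the assay, giving > 64 ug/mL, so no exact number is known for it. Compound 2 likewise sits at a limit, with > 64 ug/mL. Where compound 1 stands can therefore be said only in outline: it is among the compounds that show no measurable toxicity up to the edge of the test, due to the limit of > 64 ug/mL in this assay, at which 2 of the 2 values shown sit.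

The compound still to be measured is compound 3, `O=c1cc(NCc2ccc(F)cc2)sc2c([N+](=O)[O-])cc(C(F)(F)F)cc12`. It shares the same atoms as compound 1, joined differently: 4-fluorophenyl in place of 3-fluorophenyl on a saturated chain carbon bound to a nitrogen on an aromatic ring. The fluorine simply moves to another spot on the same ring at the end of the benzyl chain.

For the measured compounds named here, with no measured step available, the expectation rests on compound 1 alone. The change from compound 1 to compound 3 is expected to be no step beyond the scatter, a step that the limit leaves unreadable from compound 1 to compound 3. Compound 3 is expected to give 80 ug/mL in this assay, within 50 ug/mL to 150 ug/mL, most likely again reported only as a limit.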

Compound 3, half-maximal inhibitory concentration: > 64 ug/mL
Compound 3: a limit, no number; the forecaster's own chance of this, stated with the estimate: 85%; the middle value lies beyond the limit too.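

In this assay compound 3 gives > 64 ug/mL, which is a limit and not a number. For the compounds shown here, no step from compound 1 to compound 3 can be read, as the values shown end at the same edge of the test: the limit of > 64 ug/mL in this assay, at which 3 of the 3 values shown sit. The compounds shown leave open whether the place of the fluorine on the ring matters for toxicity to these cells at all.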